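Swapping the amine substituent on a kinase inhibitor core

A few compounds are considered here, and "the series" means these few. Any claim that something is new, unique, unknown or untested is made for them only; others in the source may bear on it.

Measured so far: compound 1 `CO[C@H]1CC[C@@H](Nc2cc(NCc3cnccc3C(F)(F)F)ncc2C#N)CC1` gives 5000 nM in an assay on isolated protein for inhibition of protein kinase C delta type (Homo sapiens), read by TR-FRET, with a stated time of 2 h; a lower number here means a stronger inhibitor, a higher number a weaker inhibitor; compound 2 `N#Cc1cnc(NCc2cnccc2C(F)(F)F)cc1NCC1CCOCC1` gives 5000 nM.

Compound 2 thus stands level with compound 1, and the step of no change at the digits printed from compound 1 to compound 2 (within the scatter) shows no change beyond the scatter. Compound 3 `N#Cc1cnc(NCc2cnccc2C(F)(F)F)cc1N[C@H]1CC[C@@H](C(N)=O)CC1` differs from compound 2 by 4-carbamoylcyclohexyl in place of (oxan-4-yl)methyl on a nitrogen on an aromatic ring. Going by the values given here, no measured step tests this exact change; the one step available, which also replaced the group on that nitrogen, moved nothing. Compound 3 is therefore expected to show no change at the digits printed from compound 2 to compound 3 (within the scatter), with an estimate of 5000 nM for compound 3, ranging from 1500 nM to 15000 nM.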

Compound 3, half-maximal inhibitory concentration: 400 nM
The estimate for compound 3 lay 13-fold (1.10 log units) above the measured number, outside the stated range (below it).
By their numbers in this assay, from the lowest: compound 3; then compounds 1 and 2 (each within the scatter of the next).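

Within this assay the group on a nitrogen on an aromatic ring can matter after all: 4-carbamoylcyclohexyl in place of (oxan-4-yl)methyl brings a 13-fold lower number from compound 2 to compound 3 (1.10 log units; beyond the scatter) where the earlier swap there moved nothing beyond the scatter. With the cyclohexyl ring kept, carbamoyl in place of methoxy brings a 13-fold lower number from compound 1 to compound 3 (1.10 log units; beyond the scatter) and so ties the gain to that one group rather than to the ring alone. Nothing here gives a measured reason for the gain. Still open, from the compounds shown here alone, is how a carboxylic acid, an amine or a methyl amide would read on that same ring carbon.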